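The source may report more compounds than this note shows. Statements on the series, on what has been measured and on what is new or still open speak of the compounds shown alone.

Working notes on the series. Of the compounds shown here, two have been measured in a functional assay on HCC827 cells (Homo sapiens) for inhibition, read by MTT assay, with a stated time of 48 h, tested at 10 uM; on this read-out lower numbers stand for less inhibition and higher numbers for more inhibition at the one concentration tested (going by the name of the read-out). Compound 1, `COc1cc(NC(=O)Nc2cc(Nc3cc(Br)ccc3OC)ncn2)cc(OC)c1`, gives 76.3% in this assay. Compound 2, `O=C(Nc1cc(Nc2ccc(F)c(Cl)c2)ncn1)Nc1c(Cl)cccc1Cl`, gives 53.7% in this assay. Of the two numbers, compound 1 stands highest, and the gap to compound 2 lies beyond the usual scatter of repeated measurements; the two structures differ in more than one place, so the gap is not ascribed to any single change.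

Compound 3, `COc1cc(NC(=O)Nc2cc(Nc3ccc(OC)c(I)c3)ncn2)cc(OC)c1`, is yet to be measured in this assay. Its difference from compound 1 is a single one: 3-iodo-4-methoxyphenyl in place of 5-bromo-2-methoxyphenyl on a nitrogen on an aromatic ring. One halogen-bearing, methoxy-bearing aryl group on the nitrogen on the aromatic ring is exchanged for another of the same size and count, with the halogen and methoxy positions rearranged as the names state.

Within the data shown here, with no measured step that isolates this change, the size of the step from compound 1 to compound 3 is estimated at a number 8.3 percentage points lower from compound 1 to compound 3 (within the scatter), which is within the scatter in either direction. Compound 3 is expected to give around 68% in this assay, with a range from 45% to 88%, the range being wide to allow for either a comparable number or a moderate loss.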

Compound 3, a percentage reported as inhibition, at one concentration (the size of the read-out at that concentration, not a potency): 61.7%
Beside the measured number, compound 3's estimate is 6.3 percentage points above it; the measured number falls inside the stated range.
By their numbers in this assay, from the lowest: compounds 2 and 3 (each within the scatter of the next); then compound 1.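

In this assay, the exchange of 5-bromo-2-methoxyphenyl for 3-iodo-4-methoxyphenyl on a nitrogen on an aromatic ring gives a number 14.6 percentage points lower from compound 1 to compound 3 (beyond the scatter), a modest step and the first in the series to isolate a single place, showing that the number responds to the aryl group held at this position. The two groups match in heavy-atom count, hydrogen-bond donors, hydrogen-bond acceptors and net charge, while the halogen and the arrangement of the halogen and methoxy groups change together, so this one step cannot separate those changes. No measurement at hand bears on the reason for the step.

As far as these compounds go, it remains open whether the step follows the halogen or the arrangement, a question that bromine in place of iodine on the 3-iodo-4-methoxyphenyl group would help to settle. Also open, from the compounds shown here alone, is how this position responds to aryl groups of a different kind, such as a phenyl group carrying an amine or a carboxylic acid, with the rest of compound 1 kept unchanged.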